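Shifting a Trifluoromethyl Group and the Expected Effect

This account rests on a few compounds, and the source may have more. Where it says the series, first, only, none or still open, it means among the compounds named here.

Measured compounds:
compound 1, `Nc1nc(-c2ccccc2F)cs1`: 6800 nM
compound 2, `Nc1nc(-c2ccc(C(F)(F)F)cc2F)cs1`: 260 nM

Among the measured compounds shown here, in a functional assay for agonist activity at thrombopoietin receptor (Homo sapiens) (a higher number here means that more compound is needed for the effect, a lower number that less compound is needed), compound 1 gives 6800 nM, the highest of the two numbers measured so far, and compound 2 gives 260 nM. For the measured compounds named here, the only measured step between them is a 26-fold lower number from compound 1 to compound 2 (1.42 log units; beyond the scatter). Compound 3 `Nc1nc(-c2cc(C(F)(F)F)ccc2F)cs1` has not yet been measured; it differs from compound 1 by trifluoromethyl in place of hydrogen on an aromatic carbon. The step from compound 1 to compound 2 is the only one that bears on this change, since it also introduces a trifluoromethyl group, though the two compounds carry that group on different carbons of the same ring, and nothing measured shows whether the effect depends on which carbon it occupies. A step in the same direction, a lower number, is therefore expected, but with less certainty about its size: the estimated step is a 6.8-fold lower number from compound 1 to compound 3 (0.83 log units; beyond the scatter). Compound 3 is expected to give about 1000 nM, within a range from 200 nM to 5000 nM.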

Compound 3, half-maximal effective concentration: 5200 nM
Estimate against measurement, compound 3: 5.2-fold (0.72 log units) below; the measured number lies above the stated range.
By their numbers in this assay, from the lowest: compound 2; then compounds 3 and 1 (each within the scatter of the next).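

In this assay trifluoromethyl in place of hydrogen on the aromatic carbon para to a fluoro group gives a 1.3-fold lower number from compound 1 to compound 3 (0.12 log units; within the scatter) and so, at this position, compound 3 cannot be told apart from compound 1. On a different carbon of the same ring the same group gives a 26-fold lower number from compound 1 to compound 2 (1.42 log units; beyond the scatter) and so the large step seen earlier does not follow from the presence of trifluoromethyl alone, but depends on which carbon carries it. Nothing at hand explains why the two carbons differ.

Going by these compounds, whether a methyl group, a chlorine atom or a nitrile on this same carbon would also match compound 1 remains open. So does whether trifluoromethyl would behave the same way at this carbon if the fluoro group were replaced by hydrogen.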